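Saturating the acid side chain on a biaryl acid series

The source may report more compounds than this note shows. Statements on the series, on what has been measured and on what is new or still open speak of the compounds shown alone.

- `O=C(O)CCCc1ccccc1-c1cccc(-c2ccccc2OCc2ccccc2)c1` compound 1: 11900 nM
- `O=C(O)/C=C/c1ccccc1-c1cccc(-c2ccccc2OCc2ccccc2)c1` compound 2: 72000 nM

Of the compounds shown here, two have been measured in an assay on HEK293 cells for binding affinity to prostaglandin E2 receptor EP1 subtype (Homo sapiens); a higher number here means a weaker inhibitor, a lower number a stronger inhibitor. Compound 1 `O=C(O)CCCc1ccccc1-c1cccc(-c2ccccc2OCc2ccccc2)c1` gives 11900 nM, and compound 2 `O=C(O)/C=C/c1ccccc1-c1cccc(-c2ccccc2OCc2ccccc2)c1` gives 72000 nM. Compound 2 therefore stands at the highest number of the two, its nearest neighbour being compound 1 with the step of a 6.1-fold higher number from compound 1 to compound 2 (0.78 log units; beyond the scatter) separating them.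

Compound 3 `CC(Cc1ccccc1-c1cccc(-c2ccccc2OCc2ccccc2)c1)C(=O)O` has not yet been measured. It differs from compound 2 by 2-carboxypropyl in place of 2-carboxyethenyl on an aromatic carbon. Within the data shown here, the only step that bears on this change is the one from compound 1 to compound 2, a 6.1-fold higher number from compound 1 to compound 2 (0.78 log units; beyond the scatter), where a saturated chain gave way to an unsaturated one and the number rose. Compound 3 returns to a saturated chain, though one of a different shape and length than in compound 1, so a step back downward in this assay is expected, of roughly a 3.6-fold lower number from compound 2 to compound 3 (0.56 log units; beyond the scatter). The estimate for compound 3 is accordingly 20000 nM, with a range from 6000 nM to 80000 nM.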

Compound 3, inhibition constant: 8300 nM
Compound 3: middle estimate off by 2.4-fold (0.38 log units), on the high side, within the range that was stated.
By their numbers in this assay, from the lowest: compounds 3 and 1 (each within the scatter of the next); then compound 2.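

In this assay the 2-carboxypropyl group in place of 2-carboxyethenyl brings an 8.7-fold lower number from compound 2 to compound 3 (0.94 log units; beyond the scatter) and shows that the high number of compound 2 is not shared by a second saturated chain, which the first pair alone could not show. Between the two saturated chains the step is a 1.4-fold lower number from compound 1 to compound 3 (0.16 log units; within the scatter) and leaves 3-carboxypropyl and 2-carboxypropyl indistinguishable here, so among these three compounds only the chain with the extra double bond stands apart, and none goes against that. The entering group also has 6 heavy atoms against 5, so this step alone does not separate losing the double bond from gaining a carbon, and nothing available explains the change in binding at this position.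

Going by these compounds, it remains open whether a chain longer than 3-carboxypropyl, or a tetrazole in place of the carboxylic acid, would move the number further from those of the saturated acids. On these data alone, it is also open whether the 2-carboxyethenyl penalty would hold with the double bond in its other geometry or on a different core.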